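Methoxy shift on the aryl group: compound 2 to compound 3

A few compounds are considered here, and "the series" means these few. Any claim that something is new, unique, unknown or untested is made for them only; others in the source may bear on it.

In a physicochemical assay for solubility, measured as kinetic solubility (a higher number here means a more soluble compound, a lower number a less soluble compound), compound 1 `CNc1nccc(N2CC[C@H](NC(=O)Nc3cc(OC)cc(OC)c3)C2)n1` gives 79400 nM and compound 2 `CNc1nccc(N2CC[C@H](NC(=O)Nc3ccc(OC)cc3)C2)n1` gives 92600 nM so compound 2 stands level with compound 1 within the scatter. Compound 3 `CNc1nccc(N2CC[C@H](NC(=O)Nc3cccc(OC)c3)C2)n1` is still unmeasured. It carries 3-methoxyphenyl in place of 4-methoxyphenyl on an amide-type nitrogen and the two structures have the same atoms, joined differently. Among the compounds with values here, no pair of measured compounds differing in one place is available, so this change has no direct precedent. Compound 1 at 79400 nM and compound 2 at 92600 nM differ in structure yet remain within the scatter, so no step beyond the scatter is expected in this assay in either direction. The expected step of a 1.1-fold lower number from compound 2 to compound 3 (0.04 log units; within the scatter) lies within the scatter. Compound 3 is estimated at 85000 nM with 50000 nM to 135000 nM as its range.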

Compound 3, solubility: 116000 nM
Compound 3: the middle estimate sits 1.4-fold (0.14 log units) below what was measured; low and high end bracket the measured number.
By their numbers in this assay, from the lowest: compounds 1, 2 and 3 (each within the scatter of the next).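

Within the data shown here, on the aryl group attached to the amide-type nitrogen, in this assay, 3-methoxyphenyl in place of 4-methoxyphenyl gives a 1.3-fold higher number from compound 2 to compound 3 (0.10 log units; within the scatter), the first direct reading of this methoxy shift. Hydrogen in place of methoxy on an aromatic carbon gives a 1.5-fold higher number from compound 1 to compound 3 (0.16 log units; within the scatter), so neither one-place change among these three compounds moves the number beyond the scatter. No measurement here bears on why these values stay so close.

Still open is whether this aryl group tolerates any change in this assay without a step beyond the scatter, as the methoxy variants shown span only a narrow range. An amine or a carboxylic acid on the ring, a longer alkoxy chain such as butoxy, or plain phenyl would test that.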